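The compounds below may be only part of what the source reports. "The series", "measured", "known", "first", "only" and "open" are said of these compounds alone.

Measured so far in a functional assay on CCRF-CEM cells (Homo sapiens) for cytotoxicity, read by MTT assay, with a stated time of 72 h; a lower number here means that less compound is tolerated, a higher number that more compound is tolerated:
compound 1 `CCCCC[Se]c1nc([Se]CCCCC)c2cccnc2n1`: > 100000 nM, a limit of the assay rather than a number.
compound 2 `Nc1nc([SeH])nc2ncccc12`: 92100 nM.

Among the measured compounds shown here, compound 2 carries the only measured number in this assay; the other entry is the limit of > 100000 nM in this assay, at which 1 of the 2 values shown sits. Compound 2 is thus the reference point for the step to compound 3 `CCCCC[Se]c1nc(N)c2cccnc2n1`, which is not yet measured. The change is pentyl in place of hydrogen on a selenium. For the measured compounds named here, no measured pair differing in one place is at hand, so the size of this step has no direct precedent. Compound 1, which carries pentyl on both seleniums, sits at the limit. Compound 2, with the selenium hydrogen, gives a number close to that limit. A step from compound 2 to compound 3 beyond the scatter cannot be read from these two entries alone. The expected step of a 1.1-fold higher number from compound 2 to compound 3 (0.04 log units; within the scatter) is a small rise in the tolerated concentration, within the scatter. Compound 3 is estimated at 100000 nM, with a range from 45000 nM to 220000 nM.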

Compound 3, concentration lethal to 50% of the cells: 72600 nM
Beside the measured number, compound 3's estimate is 1.4-fold (0.14 log units) above it; the measured number falls inside the stated range.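

In this assay, among the compounds shown here, the first direct reading of pentyl in place of hydrogen on a selenium is a 1.3-fold lower number from compound 2 to compound 3 (0.10 log units; within the scatter), so on a selenium whose other neighbours are aromatic carbon, this change leaves the number within the scatter. One nitrogen atom in place of a group of 6 heavy atoms on an aromatic carbon gives an at least 1.3-fold lower number from compound 1 to compound 3 (0.13 log units; that floor lies within the scatter), and only a floor can be read for this step. Compound 1 remains at a limit of the assay: the limit of > 100000 nM in this assay, at which 1 of the 3 values shown sits.

Going by these compounds, the true size of the step from compound 1 stays open, since its starting point is a limit. Also open, on these data alone, is whether a methyl, a benzyl or a longer chain such as octyl on the selenium would move the number beyond the scatter in this assay.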